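Dropping the fluoro from a weak dichloroacetamide

The compounds below may be only part of what the source reports. "The series", "measured", "known", "first", "only" and "open" are said of these compounds alone.

Measured compounds:
compound 1, `O=C(Nc1cccc(-c2ccccc2F)c1)C(Cl)Cl`: 48300 nM
compound 2, `COc1cccc(-c2cc(NC(=O)C(Cl)Cl)cc(-c3cccc(OC)c3)c2)c1`: > 30000 nM
compound 3, `CC(C)c1ccc(-c2cc(NC(=O)C(Cl)Cl)cc(-c3ccc(C(C)C)cc3)c2)cc1`: > 30000 nM

Within the data shown here, in a functional assay on KB 3-1 cells (Homo sapiens) for cytotoxicity, read by MTT assay, with a stated time of 68 h (a higher number here means a weaker inhibitor, a lower number a stronger inhibitor), compound 1 gives 48300 nM, the only actual number among the three values shown. Compound 2 reaches only a limit of the assay, > 30000 nM. Compound 3 likewise reaches only a limit, > 30000 nM. Among the measured compounds shown here, compound 1 therefore stands as the one compound with a defined, though weak, readout; the other two sit at the limit of > 30000 nM in this assay, at which 2 of the 3 values shown sit.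

Compound 4, `O=C(Nc1cccc(-c2ccccc2)c1)C(Cl)Cl`, differs from compound 1 by hydrogen in place of fluoro on an aromatic carbon. For the measured compounds named here, no pair of measured compounds differs in a single place, so no measured step guides this change. The removal of a single heavy atom in a position away from the amide is expected to move this assay little, if at all, beyond the scatter; the step from compound 1 to compound 4 is estimated at a 1.1-fold higher number from compound 1 to compound 4 (0.06 log units; within the scatter). Compound 4 is thus expected to give roughly 55000 nM, within a range from 20000 nM to 150000 nM.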

Compound 4, half-maximal inhibitory concentration: 46800 nM
Compound 4: middle estimate off by 1.2-fold (0.07 log units), on the high side; the measured number falls inside the stated range.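

In this assay, hydrogen in place of fluoro on an aromatic carbon, ortho to a large group, gives a 1.0-fold lower number from compound 1 to compound 4 (0.01 log units; within the scatter). Among these compounds, this is the first step in the set that can be read between two measured compounds that differ in one place, since the earlier compounds offered no such pair. At this position, the fluoro can be left off with no difference that stands out from the scatter, so compound 4 and compound 1 cannot be told apart in this readout.

From the compounds shown here alone, whether an amine or a carboxylic acid on this same carbon would move the readout remains open. Compound 2 and compound 3 give no number to set beside these results, as each stands at a limit of the assay: the limit of > 30000 nM in this assay, at which 2 of the 4 values shown sit.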